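The source may report more compounds than this note shows. Statements on the series, on what has been measured and on what is new or still open speak of the compounds shown alone.

Measured so far:
- compound 1 `CCc1cnc(N2CCC(n3nnc4cc(-c5ccc(S(C)(=O)=O)cc5F)ncc43)CC2)nc1`: 7 nM
- compound 2 `CCNC(=O)c1ccc(-c2cc3nnn(C4CCN(c5ncc(CC)cn5)CC4)c3cn2)c(F)c1`: 15 nM
- compound 3 `CCNC(=O)c1cc(F)c(-c2cc3nnn(C4CCN(c5ncc(CC)cn5)CC4)c3cn2)cc1F`: 2 nM

In a functional assay on HEK293 cells for agonist activity at Glucose-dependent insulinotropic receptor (Homo sapiens), read by HTRF and cAMP accumulation, with a stated time of 30 min (on this read-out higher numbers stand for an effect only at larger amounts of compound and lower numbers for an effect already at smaller amounts), compound 2 gives the highest number of the three: compound 1 sits at a 2.1-fold higher number from compound 1 to compound 2 (0.33 log units; beyond the scatter) from it, and compound 3 at a 7.5-fold lower number from compound 2 to compound 3 (0.88 log units; beyond the scatter), both steps beyond the scatter. Compound 4 `CCNC(=O)c1ccc(-c2cc3nnn(C4CCN(c5ncc(CC)cn5)CC4)c3cn2)c(Cl)c1` differs from compound 2 only by chloro in place of fluoro on an aromatic carbon. Neither measured step tests a halogen swap at this position: the step to compound 1 changes the ethylcarbamoyl group, and the step to compound 3 adds a second fluoro. With nothing that bears directly, no shift beyond the scatter is expected, so compound 4 is estimated at 15 nM (range 5 nM to 45 nM), a step of no change at the digits printed from compound 2 to compound 4 (within the scatter).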

Compound 4, half-maximal effective concentration: 13 nM
For compound 4 the middle estimate is 1.2-fold (0.06 log units) above the measured one, and the stated range covers the measured number.
By their numbers in this assay, from the lowest: compound 3; then compounds 1, 4 and 2 (each within the scatter of the next, the first and the last beyond it).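

In this assay, chloro in place of fluoro on the aromatic carbon ortho to a large group gives a 1.2-fold lower number from compound 2 to compound 4 (0.06 log units; within the scatter) and so leaves the number unchanged within the scatter for this halogen swap. Within the data shown here, the earlier steps changed the ethylcarbamoyl group or added a second fluoro, so this is the first reading of the halogen at this position. Nothing at hand gives a reason for this result.

Going by these compounds, whether a methoxy, a nitrile or an amine would be tolerated at this position remains open. So does whether chloro at this position, combined with the second fluoro of compound 3, would keep the low number of that compound.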